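Adding a methylpiperazine to an aromatic ring of compound 1

A few compounds are considered here, and "the series" means these few. Any claim that something is new, unique, unknown or untested is made for them only; others in the source may bear on it.

Compound 1 `Cn1nc(-c2ccccc2)c2cc(C(=N)Nc3ccccc3)ncc21` gives 17400 nM in a functional assay on HT-1080 cells (Homo sapiens) for cytotoxicity, read by MTT assay, with a stated time of 72 h; a lower number here means a stronger inhibitor, a higher number a weaker inhibitor. Among the three measured compounds it holds the second highest number: compound 3 `N=C(Nc1ccccc1)c1cc2c(-c3ccccc3)n[nH]c2cn1` gives 22000 nM, a gap within the scatter, whereas the step of a 3.7-fold lower number from compound 1 to compound 2 (0.57 log units; beyond the scatter) lies beyond it, with compound 2 `COc1ccc(Cn2nc(-c3ccccc3)c3cc(C(=N)Nc4ccccc4)ncc32)cc1` giving 4700 nM. Compound 4 `CN1CCN(c2ccc(NC(=N)c3cc4c(-c5ccccc5)nn(C)c4cn3)cc2)CC1` differs from compound 1 by 4-methylpiperazin-1-yl in place of hydrogen on an aromatic carbon. Among the measured compounds shown here, neither measured step touches this ring: both a 1.3-fold higher number from compound 1 to compound 3 (0.10 log units; within the scatter) and a 3.7-fold lower number from compound 1 to compound 2 (0.57 log units; beyond the scatter) alter the aromatic nitrogen, and no measured pair varies the ring that compound 4 changes. For the measured compounds named here, with no step bearing on this change, no shift beyond the scatter is expected, so compound 4 is estimated at 12000 nM, between 4000 nM and 36000 nM, an expected step of a 1.5-fold lower number from compound 1 to compound 4 (0.16 log units; within the scatter).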

Compound 4, half-maximal inhibitory concentration: 1400 nM
The estimate for compound 4 lay 8.6-fold (0.93 log units) above the measured number; the whole stated range lies above it.
By their numbers in this assay, from the lowest: compound 4; then compound 2; then compounds 1 and 3 (each within the scatter of the next).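

In this assay, 4-methylpiperazin-1-yl in place of hydrogen on the six-membered aromatic ring of carbon only gives a 12-fold lower number from compound 1 to compound 4 (1.09 log units; beyond the scatter) and leaves the rest of the molecule unchanged. Among the compounds shown here, the earlier steps altered only the aromatic nitrogen, so this is the first measured sign that this ring can respond strongly to substitution. No measured evidence explains the change. On these data alone, whether this result depends on the 4-methylpiperazin-1-yl group itself remains open. A morpholine or a dimethylamino group at the same place would help to test that.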